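The compounds below may be only part of what the source reports. "The series", "measured", "known", "first", "only" and "open" are said of these compounds alone.

Going by the values given here, compound 1 `c1cncc(-c2ccccc2OCC2=NCCN2)c1` gives 158 nM in a functional assay for activation of Alpha-1D adrenergic receptor (Homo sapiens), read by calcium flux (on this read-out higher numbers stand for an effect only at larger amounts of compound and lower numbers for an effect already at smaller amounts), and it is the only compound of the set that returns a number on this read-out. Compound 2 `Cc1cccnc1-c1ccccc1OCC1=NCCN1` returns only a limit of < 100000 nM in this assay. Compound 3 `Cc1ccnc(-c2ccccc2OCC2=NCCN2)c1` likewise returns only a limit of < 100000 nM in this assay. So the limit of < 100000 nM in this assay, at which 2 of the 3 values shown sit, covers two of the three results, and compound 1 stands on its own with a measured value.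

Compound 4 `c1ccc(-c2cnccn2)c(OCC2=NCCN2)c1` has not yet been measured in this assay. It differs from compound 1 by pyrazin-2-yl in place of pyridin-3-yl on an aromatic carbon. Among the compounds with values here, no pair of measured compounds that differ in a single place is available to gauge such a change, and the limits of compounds 2 and 3 offer no scale. The step is nonetheless expected to be a 3.8-fold higher number from compound 1 to compound 4 (0.58 log units; beyond the scatter) in this assay, toward weaker activity and somewhat beyond the usual scatter. Compound 4 is accordingly estimated at 600 nM in this assay, within a range from 100 nM to 5000 nM.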

Compound 4, half-maximal effective concentration: < 100000 nM
Compound 4: a limit, no number; the forecaster's own chance of this, stated with the estimate: 20%; the middle value lies beyond the limit too.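

Going by these compounds alone, compound 4 returns only a limit in this assay, < 100000 nM, not a number, so no step from compound 1 to compound 4 can be read. The compounds shown leave open how large a change pyrazin-2-yl in place of pyridin-3-yl actually brings.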